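Working notes: from compound 3 to compound 4

A few compounds are considered here, and "the series" means these few. Any claim that something is new, unique, unknown or untested is made for them only; others in the source may bear on it.

Measured in a functional assay on T98G cells (Homo sapiens) for inhibition, read by colorimetric assay and MTT assay, with a stated time of 72 h; on this read-out lower numbers stand for stronger inhibition and higher numbers for weaker inhibition:
- compound 1 `Cn1c2cnc1OCCCCCCCCCCOc1ccccc1-2`: 41000 nM
- compound 2 `C=CCCCCOc1ccc(OC)cc1-c1cnc(OCCC=C)n1C`: 74000 nM
- compound 3 `C=CCCCCOc1cc2ccccc2cc1-c1cnc(OCCC=C)n1C`: 32000 nM

In this assay compound 3 gives 32000 nM, which lies within the scatter of compound 1 at 41000 nM. The number for compound 3 is lower, beyond the scatter, than that of compound 2 at 74000 nM.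

Next in line is compound 4 `C=CCCCCOc1cc2ccccc2cc1-c1cnc(OCCCCC=C)n1C`, not yet measured. The change is but-3-en-1-yl in place of vinyl on a saturated chain carbon, two bonds along the chain from an oxygen on an aromatic ring. Cut one bond further out, this reads (but-3-en-1-yl)oxy to (hex-5-en-1-yl)oxy.

Among the measured compounds shown here, no measured pair differs in one place only, so no direct precedent exists for this change. The expectation therefore starts from compound 3 at 32000 nM, with no step beyond the scatter in this assay. The estimated step is a 1.1-fold lower number from compound 3 to compound 4 (0.06 log units; within the scatter). For compound 4 the estimated value is 28000 nM, with an expected range of 13000 nM to 60000 nM.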

Compound 4, half-maximal inhibitory concentration: 40000 nM
Beside the measured number, compound 4's estimate is 1.4-fold (0.15 log units) below it, within the range that was stated.
By their numbers in this assay, from the lowest: compounds 3, 4, 1 and 2 (each within the scatter of the next, the first and the last beyond it).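

In this assay, but-3-en-1-yl in place of vinyl on a saturated chain carbon, two bonds along the chain from an oxygen on an aromatic ring, gives a 1.3-fold higher number from compound 3 to compound 4 (0.10 log units; within the scatter). Among the compounds shown here, this is the first pair that differs in one place only, and it shows that going from (but-3-en-1-yl)oxy to (hex-5-en-1-yl)oxy leaves no readable difference at this position. Nothing measured on these compounds bears on why the step is this small.

Going by these compounds, whether a chain longer than hex-5-en-1-yl, or an amine or a carboxylic acid at the end of this chain, would move the number remains open. Also open, on these data alone, is whether the same change gives a similar step on the core of compound 2.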